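Esterifying the Carboxy Group of Compound 2

The source may hold more compounds than are shown below. What is called first, only, known or untested is meant among the compounds shown, and "the series" means these compounds.

Compound 2 `NCc1ccc(C(=O)Nc2ccncc2F)cc1-c1cccc(C(=O)O)c1` stands highest of the three numbers measured in an assay on isolated protein for inhibition of Rho-associated protein kinase 2 (Homo sapiens), read by radiometric assay (on this read-out lower numbers stand for stronger inhibition and higher numbers for weaker inhibition), where compound 2 gives 55 nM. Compound 1 `COC(=O)c1cccc(-c2cc(C(=O)Nc3ccncc3)ccc2CN)c1` gives 2.9 nM in this assay, and compound 3 `CCCCCOC(=O)c1cccc(-c2cc(C(=O)Nc3ccncc3)ccc2CN)c1` gives 4.9 nM. Compound 4 `COC(=O)c1cccc(-c2cc(C(=O)Nc3ccncc3F)ccc2CN)c1` is the compound yet to be measured; it differs from compound 2 by methyl in place of hydrogen on an oxygen next to a carbonyl group. Within the data shown here, the only single-point step measured so far, a 1.7-fold higher number from compound 1 to compound 3 (0.23 log units; within the scatter), shows that lengthening the ester alkyl chain leaves the number essentially unchanged, but it says nothing about carboxy against ester. Compound 2 differs from compound 1 and from compound 3 in more than one place, so the large gap between them cannot be assigned to the carboxy group alone. Among the measured compounds shown here, with no direct precedent, a step toward the lower numbers of the two esters is plausible, but its size is uncertain. He therefore expects compound 4 to give about 15 nM in this assay, within a range of 4 nM to 55 nM, which would mean an estimated step of a 3.7-fold lower number from compound 2 to compound 4 (0.56 log units; beyond the scatter).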

Compound 4, half-maximal inhibitory concentration: 7.8 nM
Beside the measured number, compound 4's estimate is 1.9-fold (0.28 log units) above it; low and high end bracket the measured number.
By their numbers in this assay, from the lowest: compounds 1, 3 and 4 (each within the scatter of the next, the first and the last beyond it); then compound 2.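

In this assay, among these compounds, the change from carboxy to methoxycarbonyl gives a 7.1-fold lower number from compound 2 to compound 4 (0.85 log units; beyond the scatter), the first reading of this change with the rest of the structure held constant. With the methoxycarbonyl group held constant, fluoro in place of hydrogen on an aromatic carbon gives a 2.7-fold higher number from compound 1 to compound 4 (0.43 log units; beyond the scatter), so the wide gap between compound 2 and compound 1 now resolves into two single-place steps, with the larger one belonging to the carboxy change. Nothing available explains either step.

The compounds shown leave open whether the change from carboxy to methoxycarbonyl has the same size on the core without the fluoro. They also leave open how a primary amide or a hydroxamic acid in that place would read.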